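Working notes: from compound 1 to compound 3

The source may hold more compounds than are shown below. What is called first, only, known or untested is meant among the compounds shown, and "the series" means these compounds.

Compound 1 `NC1(CCn2ncc(=O)[nH]c2=O)OC(=O)C(OCc2ccccc2)=C1OCc1ccccc1` is the reference point for this step. In an ADME assay on WI-38 cells (Homo sapiens) for inhibition, read by MTT assay, with a stated time of 72 h (on this read-out lower numbers stand for stronger inhibition and higher numbers for weaker inhibition), compound 1 gives > 100000 nM, which is a limit of the assay rather than a number. Among the measured compounds shown here, compound 2 `Nc1ccn(C[C@H](O)[C@H]2OC(=O)C(OCc3ccccc3)=C2OCc2ccccc2)c(=O)n1` is the only member of the series with a measured number; in this assay compound 2 gives 53900 nM. For the measured compounds named here, no two measured compounds differ in a single place, so no measured step between them exists. Where compound 1 stands on the numbers shown is therefore described only by the limit of > 100000 nM in this assay, at which 1 of the 2 values shown sits.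

Compound 3 `Cc1cn(CCC2(N)OC(=O)C(OCc3ccccc3)=C2OCc2ccccc2)c(=O)[nH]c1=O` has not yet been measured. It differs from compound 1 by a group of 9 heavy atoms (5 carbon, 2 nitrogen, 2 oxygen; one six-membered aromatic ring with 2 hetero atoms) in place of a group of 8 heavy atoms (3 carbon, 3 nitrogen, 2 oxygen; one six-membered aromatic ring with 3 hetero atoms), on a saturated chain carbon, two bonds along the chain from a saturated ring carbon. Going by the values given here, since the only known point for compound 1 is a limit, the step from compound 1 to compound 3 can be judged only against that limit, and the expectation is a step of no more than the scatter, with compound 3 likely to sit at or near the limit again. Compound 3 is therefore expected at 100000 nM, within 40000 nM to 300000 nM in this assay, an expected step of a number no higher from compound 1 to compound 3 (the limit leaves the size open).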

Compound 3, half-maximal inhibitory concentration: > 100000 nM
Compound 3: no number, only a limit (the forecaster's own chance of this, stated with the estimate: 70%); the middle value lies on the limit itself.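

Compound 1 and compound 3 both give a limit of the assay rather than a number, so no step between them can be read: the limit of > 100000 nM in this assay, at which 2 of the 3 values shown sit.

The compounds shown leave open whether the group of 9 heavy atoms in place of the group of 8 heavy atoms changes the read-out in this assay at all.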